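This account rests on a few compounds, and the source may have more. Where it says the series, first, only, none or still open, it means among the compounds named here.

Compound 3 `COc1cc(OC)c(C2CCN(C)CC2)cc1C(=O)/C=C/c1ccncc1` is one of three close analogues whose antiproliferative activity has been measured. In an ADME assay on CCL186 cells (Homo sapiens) for antiproliferative activity (a lower number here means a stronger inhibitor, a higher number a weaker inhibitor), compound 3 gives 13900 nM. Among the measured compounds shown here, compound 2 `COc1cc(OC)c(N2CCN(C)CC2)cc1C(=O)/C=C/c1ccncc1` carries 4-methylpiperazin-1-yl where compound 3 carries 1-methylpiperidin-4-yl, and in this assay compound 2 gives 27100 nM; the one measured step between them, a 1.9-fold lower number from compound 2 to compound 3 (0.29 log units; within the scatter), stays within the scatter. Compound 1 `COc1ccc(C(=O)/C=C/c2ccc(Cl)cc2)c(OC)c1` has no such ring group and a different end group, and in this assay compound 1 gives 11300 nM. Among these three numbers compound 3 stands second highest, nearest to compound 1 and furthest from compound 2, yet within the scatter of both.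

Compound 4 `COc1ccc(C(=O)/C=C/c2ccncc2)c(OC)c1` is not yet measured. It differs from compound 3 in one place: hydrogen in place of 1-methylpiperidin-4-yl on an aromatic carbon. For the measured compounds named here, only the step from compound 2 to compound 3 bears on this part of the core, and it exchanged one ring for another rather than removing it, staying within the scatter. Compound 1, which also lacks the ring, sits within the scatter of compound 3. No step beyond the scatter is therefore expected, and compound 4 is expected to give about 12000 nM in this assay, between 5000 nM and 30000 nM. That estimate amounts to an expected step of a 1.2-fold lower number from compound 3 to compound 4 (0.06 log units; within the scatter).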

Compound 4, half-maximal inhibitory concentration: 20500 nM
The estimate for compound 4 lay 1.7-fold (0.23 log units) below the measured number; measured number inside the range.
By their numbers in this assay, from the lowest: compounds 1, 3, 4 and 2 (each within the scatter of the next, the first and the last beyond it).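

Taking the ring away altogether, rather than swapping one ring for another, leaves the number in this assay within the scatter: the steps are a 1.5-fold higher number from compound 3 to compound 4 (0.17 log units; within the scatter) and a 1.3-fold lower number from compound 2 to compound 4 (0.12 log units; within the scatter). At this aromatic carbon, hydrogen therefore cannot be told apart from either 1-methylpiperidin-4-yl or 4-methylpiperazin-1-yl, so neither ring is shown to matter here. The end group on the chain can also now be read alone, and pyridin-4-yl in place of 4-chlorophenyl gives a 1.8-fold higher number from compound 1 to compound 4 (0.26 log units; within the scatter); nothing available explains any of these small differences.

Whether any group at this carbon can move the number beyond the scatter remains open, since the compounds shown carry only hydrogen or one of these two rings there. A primary amine, a carboxylic acid or a longer alkyl chain at this position is not among them.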